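This account rests on a few compounds, and the source may have more. Where it says the series, first, only, none or still open, it means among the compounds named here.

Series notes. Compound 1 `CC(CCc1cccc(OCc2ccc3ccccc3n2)c1)Cc1nnn[nH]1` gives in an assay on membranes from lung (Cavia porcellus) for binding affinity to cysteinyl leukotriene receptor (Homo sapiens) (on this read-out higher numbers stand for weaker inhibition and lower numbers for stronger inhibition), 17 nM, the lowest of the three numbers in hand. Compound 3 `O=C(O)CC1CCC(c2ccc(OCc3ccc4ccccc4n3)cc2)C1` gives 22 nM in this assay, within the scatter of compound 1; compound 2 `c1ccc2nc(COc3ccc(OCCCc4nnn[nH]4)cc3)ccc2c1` gives 69 nM in this assay, beyond it. Compound 4 `CC(CCCc1cccc(OCc2ccc3ccccc3n2)c1)C(=O)O` is not yet measured; it differs from compound 1 by 2-carboxypropyl in place of 1-((1H-tetrazol-5-yl)methyl)ethyl on a saturated chain carbon, two bonds along the chain from an aromatic carbon. Within the data shown here, the only measured step that bears on this exchange is a 3.1-fold lower number from compound 2 to compound 3 (0.50 log units; beyond the scatter), which likewise replaces a tetrazole-bearing chain with a carboxylic acid, though a cyclopentyl enters at the same time, so it carries limited weight. A step of about a 1.5-fold higher number from compound 1 to compound 4 (0.17 log units; within the scatter) in this assay is therefore expected, at most a modest shift either way. For compound 4 the estimate is 25 nM, range 8 nM to 80 nM.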

Compound 4, inhibition constant: 85 nM
Compound 4: middle estimate off by 3.4-fold (0.53 log units), on the low side; measured number above the stated range.
By their numbers in this assay, from the lowest: compounds 1 and 3 (each within the scatter of the next); then compounds 2 and 4 (each within the scatter of the next).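

In this assay, exchanging 1-((1H-tetrazol-5-yl)methyl)ethyl for 2-carboxypropyl at this chain position gives a clear loss (a 5.0-fold higher number from compound 1 to compound 4 (0.70 log units; beyond the scatter)), so the carboxylic acid does not match the tetrazole here. This runs opposite to the earlier acid-for-tetrazole change (a 3.1-fold lower number from compound 2 to compound 3 (0.50 log units; beyond the scatter)), where a cyclopentyl also enters, so that change does not carry over to this chain. No measurement in hand accounts for the difference. The compounds shown leave open whether the loss belongs to the carboxylic acid itself or to its place on the chain. They also leave open whether an acylsulfonamide or a shorter chain bearing the acid would restore the number of compound 1.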